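A few compounds are considered here, and "the series" means these few. Any claim that something is new, unique, unknown or untested is made for them only; others in the source may bear on it.

Series of three measured aryloxy ketones on a shared core, followed in a functional assay with Homo sapiens as the target; a higher number here means a weaker inhibitor, a lower number a stronger inhibitor.

Compound 1 `CC(C)[C@H](NC(=O)COc1cccc2ccccc12)C(=O)N[C@@H](CC(=O)O)C(=O)COc1cccc2ccccc12` gives 19000 nM. Compound 2 `CC(C)[C@H](NC(=O)COc1cccc2ccccc12)C(=O)N[C@@H](CC(=O)O)C(=O)COc1cccc(F)c1` gives 12000 nM. Compound 3 `CC(C)[C@H](NC(=O)COc1cccc2ccccc12)C(=O)N[C@@H](CC(=O)O)C(=O)COc1ccc(F)cc1F` gives 17600 nM. The steps among them are all small: a 1.6-fold lower number from compound 1 to compound 2 (0.20 log units; within the scatter), a 1.1-fold lower number from compound 1 to compound 3 (0.03 log units; within the scatter) and a 1.5-fold higher number from compound 2 to compound 3 (0.17 log units; within the scatter), none of which clears the scatter. On the three numbers shown, compound 3 stands second highest, with compound 1 nearest and compound 2 furthest, both within the scatter of it, so the three compounds are not separable in this assay.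

Compound 4 `CC(C)[C@H](NC(=O)COc1cccc2ccccc12)C(=O)N[C@@H](CC(=O)O)C(=O)COc1c(F)c(F)c(F)c(F)c1F` is not yet measured. Its difference from compound 3:

2,3,4,5,6-pentafluorophenyl in place of 2,4-difluorophenyl on an oxygen on a saturated carbon

Going by the values given here, the step that bears most directly on this is the one from compound 2 to compound 3, where the fluorophenyl pattern was also changed and the number moved only within the scatter; the steps from compound 1 to compound 2 and from compound 1 to compound 3 point the same way. Nothing in the series shows a change on this oxygen that reaches beyond the scatter. Compound 4 is therefore expected to stay close to compound 3, with a 1.1-fold lower number from compound 3 to compound 4 (0.04 log units; within the scatter) as the estimated step. For compound 4 the expected value in this assay is 16000 nM, with a range from 6000 nM to 45000 nM.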

Compound 4, half-maximal inhibitory concentration: 8890 nM
Estimate against measurement, compound 4: 1.8-fold (0.26 log units) above; the range from low to high includes it.
By their numbers in this assay, from the lowest: compounds 4, 2, 3 and 1 (each within the scatter of the next, the first and the last beyond it).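

In this assay, going by these compounds alone, 2,3,4,5,6-pentafluorophenyl on this oxygen gives the first step to clear the scatter (a 2.1-fold lower number from compound 1 to compound 4 (0.33 log units; beyond the scatter)), but that step is modest and stands only against naphthalen-1-yl. Against the two other fluorinated phenyl groups the steps stay within the scatter (a 2.0-fold lower number from compound 3 to compound 4 (0.30 log units; within the scatter); a 1.3-fold lower number from compound 2 to compound 4 (0.13 log units; within the scatter)), so compound 2, compound 3 and compound 4 remain unseparated despite carrying different numbers of fluorine atoms, and no trend with fluorine count can be drawn from them. The separation from naphthalen-1-yl therefore rests on a single pair, and nothing at hand accounts for it.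

Still open, as far as these compounds go, is whether a group of another kind on this oxygen, such as a saturated cyclohexyl ring or a pyridinyl ring with its ring nitrogen, would move the number beyond the scatter relative to the fluorinated phenyl groups. Also open, from the compounds shown here alone, is how this position behaves when the rest of the shared core differs, for example with a tetrazole in place of the carboxylic acid.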